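A few compounds are considered here, and "the series" means these few. Any claim that something is new, unique, unknown or untested is made for them only; others in the source may bear on it.

For the measured compounds named here, compound 2 `N/C(=N\NC(=S)N1CCSCC1)c1ccc(F)cn1` is one of two compounds measured in a functional assay on A-431 cells (Homo sapiens) for cytotoxicity, read by MTT assay, with a stated time of 72 h, tested at 100 uM; on this read-out lower numbers stand for less inhibition of growth and higher numbers for more inhibition of growth at the one concentration tested. In this assay compound 2 gives 86.6%, the higher of the two numbers, while compound 1 `N/C(=N\NC(=S)N1CCOCC1)c1ccccn1` gives 84.6%, a number that lies within the scatter of compound 2, so that no order between them can be read from these figures. Going by the values given here, compound 1 and compound 2 differ from each other in more than one place, and no step between them has been worked out.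

Compound 3 `N/C(=N\NC(=S)N1CCOCC1)c1ccc(F)cn1` has not yet been measured in this assay. It differs from compound 2 in one place: morpholin-4-yl in place of thiomorpholin-4-yl on a thiocarbonyl carbon. Among the compounds with values here, no measured pair shows what this exchange does on its own. Since compound 1 carries the morpholin-4-yl group and reaches 84.6%, the expected step from compound 2 to compound 3 is estimated as a number 1.6 percentage points lower from compound 2 to compound 3 (within the scatter), not beyond the scatter. For compound 3 the estimated value is 85%, in a range from 70% to 95%.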

Compound 3, percent growth inhibition at one concentration: 85.6%
Compound 3: middle estimate off by 0.6 percentage points, on the low side; measured number inside the range.
By their numbers in this assay, from the lowest: compounds 1, 3 and 2 (each within the scatter of the next).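

In this assay, for the compounds shown here, morpholin-4-yl in place of thiomorpholin-4-yl on a thiocarbonyl carbon gives a number 1 percentage points lower from compound 2 to compound 3 (within the scatter) and so has a measured size for the first time, with the fluoro group on the aromatic carbon present on both sides of the step. Fluoro in place of hydrogen on an aromatic carbon can also be read on its own, with morpholin-4-yl on both sides, and gives a number 1 percentage points higher from compound 1 to compound 3 (within the scatter) in this read-out. Neither step comes with any measured finding that would account for it.

Piperidin-1-yl or dimethylamino on the thiocarbonyl carbon, and chloro or methoxy on the aromatic carbon, remain open. Also open, going by these compounds, is whether these two exchanges would stay this small at lower concentrations, since each number comes from a single concentration.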